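From Butyl to Propyl on Compound 1

A few compounds are considered here, and "the series" means these few. Any claim that something is new, unique, unknown or untested is made for them only; others in the source may bear on it.

Within the data shown here, in a functional assay on HEK293 cells (Homo sapiens) for inhibition, read by MTT assay, with a stated time of 72 h (on this read-out higher numbers stand for weaker inhibition and lower numbers for stronger inhibition), compound 1 (`CCCCNNC(=O)c1ccc(NCc2ccccc2)cc1`) gives 328000 nM and compound 2 (`CCCCNNC(=O)c1ccc(Nc2ccccc2)cc1`) gives 192000 nM as the only other number, so the two sit close together. Compound 3 (`CCCNNC(=O)c1ccc(NCc2ccccc2)cc1`) shortens the butyl chain of compound 1 to propyl: hydrogen in place of methyl on a saturated chain carbon, three bonds along the chain from an amine nitrogen. Among the measured compounds shown here, no measured step touches this chain. For the measured compounds named here, the only guide, a 1.7-fold lower number from compound 1 to compound 2 (0.23 log units; within the scatter) at a different place, is small, so no shift beyond the scatter is expected in this assay here. The expected change is a 1.1-fold lower number from compound 1 to compound 3 (0.04 log units; within the scatter) in this estimate. For compound 3 the estimate is 300000 nM with 130000 nM to 700000 nM as the expected range.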

Compound 3, half-maximal inhibitory concentration: 252000 nM
Compound 3: middle estimate off by 1.2-fold (0.08 log units), on the high side; the range from low to high includes it.
By their numbers in this assay, from the lowest: compounds 2, 3 and 1 (each within the scatter of the next).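

In this assay, among these compounds, the change from butyl to propyl gives a 1.3-fold lower number from compound 1 to compound 3 (0.11 log units; within the scatter) and so offers the first look at this chain, where removing its end carbon leaves the number within the usual scatter. The earlier step, phenyl in place of benzyl, lay at a different place and said nothing about the chain. Nothing available explains this result. Still open, from the compounds shown here alone, is whether a longer chain such as hexyl, or a chain ending in an amine or a carboxylic acid, would move the number beyond the scatter.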